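The source may report more compounds than this note shows. Statements on the series, on what has been measured and on what is new or still open speak of the compounds shown alone.

For the measured compounds named here, in a functional assay on HCT-15 cells (Homo sapiens) for inhibition, read by sulforhodamine B assay (on this read-out lower numbers stand for stronger inhibition of growth and higher numbers for weaker inhibition of growth), compound 1 `Cc1cccc(CN2CC=C(CCC(=O)NO)C2=O)c1` gives 4720 nM, and compound 2 `O=C(CCC1=CCN(Cc2cccc(Cl)c2)C1=O)NO` gives 4720 nM, so compound 2 stands level with compound 1, the only step available being no change at the digits printed from compound 1 to compound 2 (within the scatter). Compound 3 `N#Cc1cccc(CN2CC=C(CCC(=O)NO)C2=O)c1` differs from compound 2 by cyano in place of chloro on an aromatic carbon. Going by the values given here, the one step that bears on this, from compound 1 to compound 2, brought no shift beyond the scatter, so the change at the same aromatic carbon is expected to give no step beyond the scatter in this assay, estimated as a 1.0-fold lower number from compound 2 to compound 3 (0.00 log units; within the scatter). Compound 3 is therefore estimated at 4700 nM, with a range of 1900 nM to 12000 nM.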

Compound 3, concentration for 50% growth inhibition: > 10000 nM
Compound 3: a limit, no number; the forecaster's own chance of this, stated with the estimate: 5%; middle value at least 2.1-fold (0.32 log units) from the limit.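

At the aromatic carbon where chloro and methyl had stood level, the group is shown to matter: in this assay, cyano gives an at least 2.1-fold higher number from compound 2 to compound 3 (0.32 log units; beyond the scatter) and an at least 2.1-fold higher number from compound 1 to compound 3 (0.32 log units; beyond the scatter). Compound 3 stands at a limit of the assay and not at a number, so both steps give only a minimum size: the limit of > 10000 nM in this assay, at which 1 of the 3 values shown sits. This position therefore separates cyano from methyl and chloro, which compound 1 and compound 2 alone could not show. Open, from the compounds shown here alone, is whether other groups on this carbon, such as an amine or methoxy, would stay level with methyl and chloro or follow cyano.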